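The compounds below may be only part of what the source reports. "The series", "measured", "known", "first", "only" and "open" are said of these compounds alone.

Measured compounds in a functional assay on HeLa cells (Homo sapiens) for antiproliferative activity, read by cell counting, with a stated time of 3 days; on this read-out higher numbers stand for weaker inhibition and lower numbers for stronger inhibition:
- compound 1 `CC(=O)c1ccc(Oc2ccccc2NC(C)=C2C(=O)CC(c3ccccc3)CC2=O)cc1` gives 130 nM
- compound 2 `COc1ccc(Oc2ccccc2NC(C)=C2C(=O)CC(c3ccccc3)CC2=O)cc1OC` gives 54 nM
- compound 3 `COc1cc(Oc2ccccc2NC(C)=C2C(=O)CC(c3ccccc3)CC2=O)ccc1N` gives 33 nM

Compound 1 holds the highest of the three numbers in this assay; the nearest is compound 2 (a 2.4-fold lower number from compound 1 to compound 2 (0.38 log units; beyond the scatter)) and the furthest compound 3 (a 3.9-fold lower number from compound 1 to compound 3 (0.60 log units; beyond the scatter)). Both of those steps exchange the aryl group on the oxygen on the aromatic ring and both lower the number beyond the scatter, though only modestly. The step from compound 2 to compound 3 (a 1.6-fold lower number from compound 2 to compound 3 (0.21 log units; within the scatter)) stays within the scatter.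

Compound 4 `CC(Nc1ccccc1Oc1cccc(N)c1)=C1C(=O)CC(c2ccccc2)CC1=O` is not yet measured. Its difference from compound 1 is 3-aminophenyl in place of 4-acetylphenyl on an oxygen on an aromatic ring. This is a change of the same kind as the two measured steps from compound 1, so a modest lowering of the number is expected, of roughly the size seen there (a 2.6-fold lower number from compound 1 to compound 4 (0.41 log units; beyond the scatter)). A larger or smaller step cannot be ruled out on two examples. The expected value for compound 4 in this assay is 50 nM, with a range from 20 nM to 130 nM.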

Compound 4, half-maximal inhibitory concentration: 82 nM
Beside the measured number, compound 4's estimate is 1.6-fold (0.21 log units) below it; the measured number falls inside the stated range.
By their numbers in this assay, from the lowest: compounds 3, 2, 4 and 1 (each within the scatter of the next, the first and the last beyond it).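

In this assay, the exchange of 4-acetylphenyl for 3-aminophenyl on this oxygen stays within the scatter (a 1.6-fold lower number from compound 1 to compound 4 (0.20 log units; within the scatter)), unlike the two earlier exchanges of 4-acetylphenyl at the same place. The 3-aminophenyl group also stays within the scatter of 3,4-dimethoxyphenyl (a 1.5-fold higher number from compound 2 to compound 4 (0.18 log units; within the scatter)), but lies beyond it from 4-amino-3-methoxyphenyl (a 2.5-fold higher number from compound 3 to compound 4 (0.40 log units; beyond the scatter)), so an amino group on this aryl ring is not enough on its own to reach the number of compound 3. No measurement at hand bears on the reason for these differences.

Open, going by these compounds, is where 4-aminophenyl and 3-methoxyphenyl would stand on this oxygen, which would show how the amino and methoxy groups of compound 3 act separately. Also open, on these data alone, is how a carboxylic acid on this aryl ring would read out.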